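Removing one chloro from an amide that shows no cytotoxicity

The source may hold more compounds than are shown below. What is called first, only, known or untested is meant among the compounds shown, and "the series" means these compounds.

In a functional assay on K562 cells (Homo sapiens) for cytotoxicity, with a stated time of 72 h (on this read-out lower numbers stand for stronger inhibition and higher numbers for weaker inhibition), compound 1 `CC(C)[C@H](NC(=O)c1ccc(Cl)cc1O)C(=O)Nc1ccc(Cl)c(Cl)c1` gives only a limit of > 10000 nM. Compound 2 `C[C@H](NC(=O)c1ccc(Cl)cc1O)C(=O)Nc1ccc(Cl)c(Cl)c1` likewise gives only a limit, > 12500 nM. The step that the two limits leave unreadable from compound 1 to compound 2 therefore cannot be sized. Compound 3 `CC(C)[C@H](NC(=O)c1ccc(Cl)cc1O)C(=O)Nc1ccc(Cl)cc1` differs from compound 1 by hydrogen in place of chloro on an aromatic carbon. Within the data shown here, no measured step touches this change, and both measured values sit at limits (the limit of > 10000 nM in this assay, at which 1 of the 2 values shown sits, (the limit of > 12500 nM in this assay, at which 1 of the 2 values shown sits)); the expectation rests on the shared core alone. Compound 3 is expected to remain without measurable inhibition, an estimated 15000 nM (range 4000 nM to 60000 nM), with the expected step that the limit leaves unreadable from compound 1 to compound 3 being none beyond the scatter.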

Compound 3, half-maximal inhibitory concentration: > 10000 nM
Compound 3: no number, only a limit; the forecaster's own chance of this, stated with the estimate: 80%; the middle value does not contradict the limit.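

In this assay compound 3 gives > 10000 nM, a limit and not a number, and compound 1 also gives only a limit, so the step between them cannot be read. The compounds shown leave open whether the lost chloro changes cytotoxicity at all, as none of them gives a number.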